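The compounds below may be only part of what the source reports. "The series", "measured", "known", "first", "only" and "open" are said of these compounds alone.

Three compounds have been measured in an ADME assay on cells (Hepatocyte, Homo sapiens) for metabolic stability, with a stated time of 30 min; a lower number here means that less of the compound is left, a higher number that more of the compound is left:

Compound 1 `O=C(NC1CCC(CN2CCN(c3cc(=O)c4cc(C(F)(F)F)cc([N+](=O)[O-])c4s3)CC2)CC1)c1ccccc1`: 92.9%
Compound 2 `O=c1cc(N2CCN(CC3CCCCC3)CC2)sc2c(NO)cc(C(F)(F)F)cc12`: 19.1%
Compound 3 `Nc1cc(C(F)(F)F)cc2c(=O)cc(N3CCN(CC4CCCCC4)CC3)sc12`: 0.9%

Compound 1 stands highest of the three, and its gaps to compound 2 and compound 3 both lie beyond the usual scatter. Compound 4 `O=C(OC1CCC(CN2CCN(c3cc(=O)c4cc(C(F)(F)F)cc([N+](=O)[O-])c4s3)CC2)CC1)C1CCCCC1` has not yet been measured. It keeps the core of compound 1 and differs as follows: (cyclohexylcarbonyl)oxy in place of benzamido on a saturated ring carbon. In words, (cyclohexylcarbonyl)oxy stands in place of benzamido on a saturated ring carbon.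

For the measured compounds named here, no measured step covers this exchange. Going by the values given here, the only one available is a number 18.2 percentage points lower from compound 2 to compound 3 (beyond the scatter), and it lies elsewhere in the molecule, so it shows only that one local change can move this assay beyond the scatter. With compound 1 at 92.9%, there is little room for a rise, so any clear movement is expected to be downward. The expected change is estimated as a number 37.9 percentage points lower from compound 1 to compound 4 (beyond the scatter), a larger step than the measured one, though the range is wide. Compound 4 is expected at 55%, with an estimated range from 15% to 90%.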

Compound 4, percent of the compound remaining: 2.8%
Beside the measured number, compound 4's estimate is 52.2 percentage points above it; measured number outside the range, below it.
By their numbers in this assay, from the lowest: compounds 3 and 4 (each within the scatter of the next); then compound 2; then compound 1.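

In this assay, the group on the saturated ring carbon proves decisive with the rest of compound 1 unchanged: a number 90.1 percentage points lower from compound 1 to compound 4 (beyond the scatter), a far larger step than a number 18.2 percentage points lower from compound 2 to compound 3 (beyond the scatter). The high number of compound 1 therefore does not come from the shared core alone, as that core also carries the much lower number of compound 4 2.8%. The exchange alters two features at once, nitrogen to oxygen in the link and an aromatic to a non-aromatic ring, and no measurement here explains the loss.

It remains open whether the link or the ring accounts for the step: neither a cyclohexanecarboxamido group nor a benzoyloxy group stands among the compounds shown. Going by these compounds, how an amine or a carboxylic acid on this saturated ring carbon would fare in this assay also remains open.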